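This account rests on a few compounds, and the source may have more. Where it says the series, first, only, none or still open, it means among the compounds named here.

Compound 1 `CC(C)=CCC/C(C)=C/C[C@]12C(=O)CC(=O)[C@](CC=C(C)C)(C[C@@H](CC=C(C)C)C1(C)C)C2=O`, compound 2 `CC(C)=CCC/C(C)=C/C[C@@H]1C[C@]2(CC=C(C)C)C(=O)[C@@](CC=C(C)C)(C(=O)C(C(=O)c3ccc(O)c(O)c3)=C2O)C1(C)C` and compound 3 `CC(C)=CCC/C(C)=C/C[C@]12C[C@@H](CC=C(C)C)C(C)(C)[C@](C/C=C(\C)CCC=C(C)C)(C(=O)CC1=O)C2=O` are the measured compounds. In a functional assay on HCT-116 cells (Homo sapiens) for inhibition (on this read-out lower numbers stand for stronger inhibition and higher numbers for weaker inhibition), compound 1 gives 10.9 ug/mL. Compound 2 gives only a limit of this assay, > 20 ug/mL. Compound 3 likewise gives only a limit, > 20 ug/mL.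

From compound 3 to compound 1 the change is hydrogen in place of 3-methylbut-2-en-1-yl on a saturated chain carbon bound to a double-bonded chain carbon, and the step it made in this assay was an at least 1.8-fold lower number from compound 3 to compound 1 (0.26 log units; that floor lies within the scatter). How the core of compound 2 differs from the core of compound 3 is not broken down here. Within the data shown here, compound 4 `CC(C)=CC[C@@H]1C[C@]2(CC=C(C)C)C(=O)[C@@](CC=C(C)C)(C(=O)C(C(=O)c3ccc(O)c(O)c3)=C2O)C1(C)C` has not yet been measured; it differs from compound 2 by hydrogen in place of 3-methylbut-2-en-1-yl on a saturated chain carbon bound to a double-bonded chain carbon, the same change as the one from compound 3 to compound 1. Compound 2 sits at the limit of > 20 ug/mL in this assay, at which 2 of the 3 values shown sit, the same starting point as the measured step. For compound 4 a step of an at least 1.3-fold lower number from compound 2 to compound 4 (0.12 log units; that floor lies within the scatter) is expected, resting on the measured step of an at least 1.8-fold lower number from compound 3 to compound 1 (0.26 log units; that floor lies within the scatter). Compound 4 is therefore estimated at 15 ug/mL, between 6 ug/mL and 40 ug/mL, with a fair chance that this assay again reports only a limit.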

Compound 4, half-maximal inhibitory concentration: 9.22 ug/mL
Compound 4: middle estimate off by 1.6-fold (0.21 log units), on the high side; the range from low to high includes it.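

In this assay, putting hydrogen in place of 3-methylbut-2-en-1-yl on a saturated chain carbon bound to a double-bonded chain carbon gave an at least 2.1-fold lower number from compound 2 to compound 4 (0.33 log units; beyond the scatter). Set beside the earlier case, the change points the same way on both cores: the same change on two cores in this assay, an at least 1.8-fold lower number (0.26 log units; that floor lies within the scatter) from compound 3 to compound 1 and an at least 2.1-fold lower number (0.33 log units; beyond the scatter) from compound 2 to compound 4; the limit leaves it open whether they differ. This shows that the direction carried over from one core to the other, but the starting compound of each step gives only a limit, so neither step has a known size and two cores set no rule for the series: the limit of > 20 ug/mL in this assay, at which 2 of the 4 values shown sit.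

The compounds shown leave open what a different group would do at this place, such as a methyl group, a saturated pentyl chain or a chain ending in an amine, since only hydrogen, 3-methylbut-2-en-1-yl and 3,7-dimethylocta-2,6-dien-1-yl appear in these pairs. They also leave open whether the same change would point the same way on any further core or in any other read-out.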